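The source may report more compounds than this note shows. Statements on the series, on what has been measured and on what is new or still open speak of the compounds shown alone.

Compound 1 `CCCCNc1nc(C(F)(F)F)ccc1CNC(=O)C(C)c1ccc(NS(C)(=O)=O)c(F)c1` gives 293 nM in a functional assay on CHO-K1 cells for antagonist activity at transient receptor potential cation channel subfamily V member 1 (Homo sapiens), read by FLIPR (on this read-out lower numbers stand for stronger inhibition and higher numbers for weaker inhibition), the second highest of three numbers: compound 3 `Cc1ccc(Cl)cc1Nc1nc(C(F)(F)F)ccc1CNC(=O)C(C)c1ccc(NS(C)(=O)=O)c(F)c1` gives 140 nM, and compound 2 `CC(C(=O)NCc1ccc(C(F)(F)F)nc1Nc1ccccc1)c1ccc(NS(C)(=O)=O)c(F)c1` gives 1400 nM. Compound 4 `CC(C(=O)NCc1ccc(C(F)(F)F)nc1NCc1ccccc1)c1ccc(NS(C)(=O)=O)c(F)c1` differs from compound 1 by phenyl in place of propyl on a saturated chain carbon bound to a nitrogen on an aromatic ring. Among the measured compounds shown here, two measured steps bear on this change. Swapping butyl for phenyl gave a 4.8-fold higher number from compound 1 to compound 2 (0.68 log units; beyond the scatter), whereas swapping it for 5-chloro-2-methylphenyl gave a 2.1-fold lower number from compound 1 to compound 3 (0.32 log units; beyond the scatter). In benzyl the phenyl sits on a saturated chain carbon rather than directly on the ring nitrogen, so a step smaller than the one to phenyl is expected, most likely a modest weakening or none beyond the scatter. Compound 4 is therefore estimated at 450 nM, within 150 nM to 1300 nM, meaning an expected 1.5-fold higher number from compound 1 to compound 4 (0.19 log units; within the scatter).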

Compound 4, half-maximal inhibitory concentration: 203 nM
Estimate against measurement, compound 4: 2.2-fold (0.35 log units) above; measured number inside the range.
By their numbers in this assay, from the lowest: compounds 3, 4 and 1 (each within the scatter of the next, the first and the last beyond it); then compound 2.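

Carried on one saturated carbon, a phenyl ring is accepted at this position: butyl to benzyl stays within the scatter (a 1.4-fold lower number from compound 1 to compound 4 (0.16 log units; within the scatter)), as does 5-chloro-2-methylphenyl to benzyl (a 1.5-fold higher number from compound 3 to compound 4 (0.16 log units; within the scatter)). Phenyl set directly on the nitrogen stands apart, with benzyl in its place clearly stronger (a 6.9-fold lower number from compound 2 to compound 4 (0.84 log units; beyond the scatter)). No supporting measurement accounts for this. Still open, on these data alone, is whether a longer link, as in phenethyl, or a saturated ring, as in cyclohexylmethyl, would fit here, and whether chlorine and methyl on the benzyl ring would matter.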